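From 4-chlorophenyl to 3-iodophenyl: estimating one swap

This account rests on a few compounds, and the source may have more. Where it says the series, first, only, none or still open, it means among the compounds named here.

Compound 1 `Cc1ccc2nc(NC(c3cn(-c4ccccc4)nc3-c3cccc([N+](=O)[O-])c3)c3c(O)ccc4ccccc34)sc2c1`: 57400 nM
Compound 2 `COc1ccc2nc(NC(c3cn(-c4ccccc4)nc3-c3ccc(Cl)cc3)c3c(O)ccc4ccccc34)sc2c1`: 34500 nM

Both compounds were tested in a functional assay on A549 cells (Homo sapiens) for antiproliferative activity, read by MTT assay, with a stated time of 48 h; on this read-out lower numbers stand for stronger inhibition and higher numbers for weaker inhibition. Compound 2 lies within the usual scatter of compound 1, so the two numbers cannot be told apart, and neither can be called the better compound. The two also differ in more than one place, so their comparison does not show what any single change does.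

The next compound to be tested is compound 3 `COc1ccc2nc(NC(c3cn(-c4ccccc4)nc3-c3cccc(I)c3)c3c(O)ccc4ccccc34)sc2c1`. It has 3-iodophenyl in place of 4-chlorophenyl on an aromatic carbon of the five-membered aromatic ring with 2 nitrogen (3-iodophenyl in place of 4-chlorophenyl on an aromatic carbon). The rest of compound 2 stays as it is.

The evidence for a prediction is thin. Within the data shown here, no measured pair isolates this swap, but compound 1 at 57400 nM and compound 2 at 34500 nM stay close despite their structural differences. No change beyond the scatter is therefore expected in this assay, in either direction. The expected step is a 1.0-fold lower number from compound 2 to compound 3 (0.02 log units; within the scatter). For compound 3 the estimated value is 33000 nM, with an expected range from 14000 nM to 75000 nM.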

Compound 3, half-maximal inhibitory concentration: 39300 nM
The estimate for compound 3 lay 1.2-fold (0.08 log units) below the measured number, and the stated range covers the measured number.
By their numbers in this assay, from the lowest: compounds 2, 3 and 1 (each within the scatter of the next).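

Among these compounds, this is the first pair that differs in one place only, so the swap of 4-chlorophenyl for 3-iodophenyl can now be read on its own: in this assay it gives a 1.1-fold higher number from compound 2 to compound 3 (0.06 log units; within the scatter) and thus no change that can be told from scatter. The two groups have the same count of heavy atoms and neither carries a hydrogen-bond donor or acceptor, but the swap alters two things at once, the halogen and where it sits on the phenyl ring. Even so, at this aromatic carbon of the five-membered ring, this assay does not tell the two groups apart, and no measurement here explains that result or separates the part played by chlorine from that played by iodine.

On these data alone, it remains open whether a different kind of substituent on this phenyl ring, such as an amine or a carboxylic acid in place of the iodine, would shift the number beyond the scatter. As far as these compounds go, whether a phenyl ring with no halogen at all would behave like these two groups also remains open.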